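A few compounds are considered here, and "the series" means these few. Any claim that something is new, unique, unknown or untested is made for them only; others in the source may bear on it.

Measured so far in an assay on isolated protein for displacement of a labelled ligand from Alpha-1B adrenergic receptor (Homo sapiens); on this read-out lower numbers stand for stronger inhibition and higher numbers for weaker inhibition:
- compound 1, `CC(C)Oc1ccccc1N1CCN(Cc2cc(CN3CCCC3=O)no2)CC1`: 2990 nM
- compound 2, `O=C1CCCCCN1Cc1cc(CN2CCN(c3ccccc3Oc3ccccc3)CC2)on1`: > 5000 nM
- compound 3, `CC(C)Oc1ccccc1N1CCN(Cc2nc(CN3CCCC3=O)co2)CC1`: > 5000 nM

Compound 3 gives only a limit in this assay, not a number. It sits at the limit of > 5000 nM in this assay, at which 2 of the 3 values shown sit, so its true value may be anywhere beyond that point. Compound 1 gives a number, while compound 2, which carries the larger lactam ring on a different core, also returns only a limit.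

Compound 4, `CC(C)Oc1ccccc1N1CCN(Cc2nc(CN3CCCCC3=O)co2)CC1`, is compound 3 with 2-oxopiperidin-1-yl in place of 2-oxopyrrolidin-1-yl on a saturated chain carbon bound to an aromatic carbon. Among the compounds with values here, no measured pair differs in just this way, so the size of the step can only be judged loosely. The expectation is for no step beyond the scatter, with compound 4 remaining weak, estimated at 8000 nM (range 3000 nM to 30000 nM), a step that the limit leaves unreadable from compound 3 to compound 4 from its parent.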

Compound 4, inhibition constant: > 5000 nM
Compound 4: only a limit was reported (the forecaster's own chance of this, stated with the estimate: 70%); the middle value does not contradict the limit.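

Compound 3 and compound 4 each give only a limit, so no step between them can be read: the limit of > 5000 nM in this assay, at which 3 of the 4 values shown sit.

Still open, as far as these compounds go, is how weak either compound truly is, and whether 2-oxopiperidin-1-yl in place of 2-oxopyrrolidin-1-yl changes the binding at all.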